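The source may hold more compounds than are shown below. What is called first, only, known or untested is meant among the compounds shown, and "the series" means these compounds.

In a physicochemical assay for solubility, read by HPLC, in phosphate buffer, with a stated time of 24 h, at pH 7.4, tested at 100 uM (on this read-out higher numbers stand for higher solubility and lower numbers for lower solubility), compound 1 (`C[C@@H](Nc1c(NCCCCCC(=O)NO)c(=O)c1=O)c1ccccc1`) gives 80000000 nM. Going by the values given here, only one other compound offers a comparison: compound 2 (`Cc1cccc([C@@H](C)Nc2c(NCCCCCC(=O)NO)c(=O)c2=O)c1`) gives 89000000 nM, so compound 1 sits level with it within the scatter. Compound 3 (`Cc1ccccc1Nc1c(NCCCCCC(=O)NO)c(=O)c1=O`) keeps the shared core but has 2-methylphenyl in place of 1-phenylethyl on a nitrogen on an aromatic ring. Among the compounds with values here, only one measured step bears on this change, and only in part. Putting methyl in place of hydrogen on an aromatic carbon gave a 1.1-fold higher number from compound 1 to compound 2 (0.05 log units; within the scatter). That step shows a small edit to the aromatic group leaving the number flat, but it says nothing about replacing the whole group. No step beyond the scatter is therefore expected, although the uncertainty is wide: the expected step is a 1.1-fold lower number from compound 1 to compound 3 (0.06 log units; within the scatter). Compound 3 is estimated at 70000000 nM, with an expected range from 30000000 nM to 100000000 nM.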

Compound 3, solubility: 89000000 nM
Compound 3: the middle estimate sits 1.3-fold (0.10 log units) below what was measured; measured number inside the range.
By their numbers in this assay, from the lowest: compounds 1, 2 and 3 (each within the scatter of the next).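

In this assay, replacing the whole group on this nitrogen, with 2-methylphenyl in place of 1-phenylethyl, gives a 1.1-fold higher number from compound 1 to compound 3 (0.05 log units; within the scatter) and so stays within the scatter. The earlier pair covered only a small edit to the aromatic ring, whereas this step exchanges the entire group, and the number still does not move beyond the scatter. The exchange also removes the defined stereocentre of 1-phenylethyl, yet compound 1 and compound 3 cannot be told apart on this read-out, and nothing measured here offers an explanation for that.

All three compounds carry a six-membered aromatic ring of carbon only in the group on this nitrogen. On these data alone, what a pyridine ring, or a carboxylic acid on the aromatic ring, would do to the number remains open.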